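Replacing the carbamoylamino link with a direct trifluoromethylphenyl urea

The compounds below may be only part of what the source reports. "The series", "measured", "known", "first", "only" and "open" are said of these compounds alone.

Measured so far in a functional assay on SW-620 cells (Homo sapiens) for inhibition, read by MTT assay, with a stated time of 72 h; a higher number here means a weaker inhibitor, a lower number a stronger inhibitor:
compound 1 `COc1cc(NC(C)CCCNC(=O)NNC(=O)Nc2cc(C(F)(F)F)cc(C(F)(F)F)c2)c2ncccc2c1`, 16000 nM
compound 3 `COc1cc(NC(C)CCCNC(=O)NNC(=O)Nc2ccc(C(F)(F)F)cc2)c2ncccc2c1`, 12000 nM
compound 2 `COc1cc(NC(C)CCCNC(=O)NNC(=O)Nc2ccc(F)cc2)c2ncccc2c1`, see below

Compound 2 gives > 100000 nM in this assay, which is a limit of the assay and not a number; it sits at the limit of > 100000 nM in this assay, at which 1 of the 3 values shown sits, the weakest end of what is shown. Compound 4 `COc1cc(NC(C)CCCNC(=O)Nc2cccc(C(F)(F)F)c2)c2ncccc2c1` differs from compound 2 in one place: 3-(trifluoromethyl)phenyl in place of ((4-fluorophenyl)carbamoyl)amino on an amide-type nitrogen. Among the compounds with values here, one measured step bears on this: an at least 8.3-fold lower number from compound 2 to compound 3 (0.92 log units; beyond the scatter), and with two such groups compound 1 gives 16000 nM. Within the data shown here, no measured pair shows the carbamoylamino link removed, so that half of the change is untested. Compound 4 is expected near 15000 nM, within 3000 nM to 80000 nM. The step this estimate means, an at least 6.6-fold lower number from compound 2 to compound 4 (0.82 log units; beyond the scatter), is expected to run toward lower numbers, as the trifluoromethyl compounds do.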

Compound 4, half-maximal inhibitory concentration: 22000 nM
The estimate for compound 4 lay 1.5-fold (0.17 log units) below the measured number; the measured number falls inside the stated range.
By their numbers in this assay, from the lowest: compounds 3, 1 and 4 (each within the scatter of the next). At a limit, above all of these: compound 2.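

In this assay the replacement on the amide-type nitrogen gives an at least 4.5-fold lower number from compound 2 to compound 4 (0.65 log units; beyond the scatter) and shows that this place tolerates loss of the carbamoylamino link that compound 1 and compound 3 keep. On these data alone, compound 2 stands at a limit of the assay and not at a number, so the true size of this step stays unknown.

The shown compounds do not separate the effect of removing the link from that of adding 3-(trifluoromethyl)phenyl. As far as these compounds go, an amine or a carboxylic acid on the phenyl ring remains open, as does a plain phenyl on this nitrogen.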